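The compounds below may be only part of what the source reports. "The series", "measured", "known", "first", "only" and "open" are said of these compounds alone.

Among the measured compounds shown here, compound 2 `CCCS(=O)(=O)Nc1ccc(F)c(C(=O)c2n[nH]c3ncc(-c4cccc(C(F)(F)F)c4)cc23)c1F` stands highest of the two numbers measured so far: in an assay for binding affinity to dual specificity mitogen-activated protein kinase kinase 4 (Homo sapiens), read by KINOMEscan, tested at 100 nM (a lower number here means a stronger effect, a higher number a weaker effect of the compound at the concentration tested), compound 2 gives 57%, whereas compound 1 `CCCS(=O)(=O)Nc1ccc(F)c(C(=O)c2n[nH]c3ncc(-c4ccc(O)cc4)cc23)c1F` gives 0.75%. For the measured compounds named here, the single step between them, a number 56.3 percentage points higher from compound 1 to compound 2 (beyond the scatter), shows how strongly the read-out depends on the aromatic group hanging from the shared core. Compound 3 `CCCS(=O)(=O)Nc1ccc(F)c(C(=O)c2n[nH]c3ncc(-c4ccc(C(=O)O)cc4)cc23)c1F` has not yet been measured. It differs from compound 2 in one place: 4-carboxyphenyl in place of 3-(trifluoromethyl)phenyl on an aromatic carbon. Going by the values given here, only the step from compound 1 to compound 2 bears on this change, and it was large. Like the 4-hydroxyphenyl of compound 1, the 4-carboxyphenyl entering here carries one hydrogen-bond donor and one hydrogen-bond acceptor, while the 3-(trifluoromethyl)phenyl leaving carries none. The number for compound 3 is therefore expected to fall back toward the low value of compound 1, though how far it falls is uncertain. The expected step is a number 47 percentage points lower from compound 2 to compound 3 (beyond the scatter), a decrease well beyond the scatter. Compound 3 is estimated to give about 10% in this assay, within a range from 1% to 45%.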

Compound 3, a percentage reported as activity, at one concentration (the size of the read-out at that concentration, not a potency): 0.1%
For compound 3 the middle estimate is 9.9 percentage points above the measured one; the whole stated range lies above it.
By their numbers in this assay, from the lowest: compounds 3 and 1 (each within the scatter of the next); then compound 2.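

The high number of compound 2 now looks like the exception rather than the rule at this position: in this assay, a second, different 4-substituted phenyl carrying a hydrogen-bond donor and acceptor gives a number 56.9 percentage points lower from compound 2 to compound 3 (beyond the scatter), so the low read-out does not belong to the 4-hydroxyphenyl alone. The exchange of hydroxy for carboxy on the same ring gives a number 0.7 percentage points lower from compound 1 to compound 3 (within the scatter), meaning that this assay cannot tell these two groups apart, and both compounds remain far from compound 2 in the printed values. Nothing shown here gives a measured reason for this contrast between the groups.

From the compounds shown here alone, the two low compounds share both the 4-position of their substituent and the presence of a hydrogen-bond donor and acceptor, while compound 2 differs in both respects, so it remains open which of the two features matters. A 4-(trifluoromethyl)phenyl group or a 3-carboxyphenyl group would separate them, and a plain phenyl or a 4-aminophenyl group would show how much any substituent on this ring contributes.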